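From Pyrrolyl to Dimethylamino on the Side Chain

This account rests on a few compounds, and the source may have more. Where it says the series, first, only, none or still open, it means among the compounds named here.

Of the compounds shown here, three have so far been measured in a functional assay on K562 cells (Homo sapiens) for antiproliferative activity, read by MTT assay, with a stated time of 48 h; a lower number here means a stronger inhibitor, a higher number a weaker inhibitor.

Compound 1 `Cn1cc(C2=C(c3n[nH]c4ncccc34)C(=O)NC2=O)c2ccccc21` gives > 100000 nM, which is a limit of the assay.
Compound 2 `Cn1cc(C2=C(c3nn(CCn4ccnc4)c4ncccc34)C(=O)NC2=O)c2ccccc21` gives > 100000 nM, again a limit of the assay.
Compound 3 `Cn1cc(C2=C(c3nn(CCCn4cccc4)c4ncccc34)C(=O)N(c3ccccc3)C2=O)c2ccccc21` gives 36600 nM.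

For the measured compounds named here, compound 3 therefore stands as the only real number in the set; the other two values sit at the limit of > 100000 nM in this assay, at which 2 of the 3 values shown sit. Going by the values given here, the single measured step, a step that the two limits leave unreadable from compound 1 to compound 2, runs between two limits, so its size cannot be read, and no measured step bears on the change now considered.

The unmeasured compound 4 `CN(C)CCCn1nc(C2=C(c3cn(C)c4ccccc34)C(=O)N(c3ccccc3)C2=O)c2cccnc21` differs from compound 3 in one place: dimethylamino in place of 1H-pyrrol-1-yl on a saturated chain carbon, three bonds along the chain from an aromatic nitrogen. Nothing measured here speaks to such a swap, so the account rests on compound 3 alone. With no readable step to draw on, the expected step is a 1.2-fold lower number from compound 3 to compound 4 (0.09 log units; within the scatter), that is, none beyond the scatter. Compound 4 is accordingly estimated at 30000 nM, with a range from 10000 nM to 100000 nM.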

Compound 4, half-maximal inhibitory concentration: 1700 nM
The estimate for compound 4 lay 18-fold (1.25 log units) above the measured number, and the stated range ends above it.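

In this assay the end of this side chain proves to be a place where a single change matters: dimethylamino in place of 1H-pyrrol-1-yl on a saturated chain carbon, three bonds along the chain from an aromatic nitrogen, gives a 22-fold lower number from compound 3 to compound 4 (1.33 log units; beyond the scatter). For the compounds shown here, this is the first readable step in the set, as the step between the earlier compounds runs between two limits and cannot be read. Nothing shown here points to a cause for this step.

The compounds shown leave open whether the change belongs to dimethylamino in particular or would also appear with another amine, such as pyrrolidine or morpholine, at the end of the chain. Going by these compounds, it also remains open how a shorter or longer chain carrying dimethylamino, or a carboxylic acid in its place, would read.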